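Swapping 4-fluorobenzyl for allyl on compound 3

A few compounds are considered here, and "the series" means these few. Any claim that something is new, unique, unknown or untested is made for them only; others in the source may bear on it.

Compound 1 `CN(C)CCNc1ccnc2cc(OCc3ccc(F)cc3)ccc12`: 790 nM
Compound 2 `C=CCOc1ccc2c(NCCN(C)C)ccnc2c1`: 1660 nM
Compound 3 `CN(C)CCCNc1ccnc2cc(OCc3ccc(F)cc3)ccc12`: 1570 nM
Compound 4 `C=CCOc1ccc2c(NCCCN(C)C)ccnc2c1`: not yet measured

All of these numbers come from a functional assay on HepG2 cells (Homo sapiens) for cytotoxicity, read by MTT assay, with a stated time of 48 h; a lower number here means a stronger inhibitor, a higher number a weaker inhibitor. Compound 3, at 1570 nM, lies within the usual scatter of compound 2, at 1660 nM. Its distance from the remaining compound is also within the scatter: a 2.0-fold higher number from compound 1 to compound 3 (0.30 log units; within the scatter).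

Compound 4 differs from compound 3 in one place: vinyl in place of 4-fluorophenyl on a saturated chain carbon bound to an oxygen on an aromatic ring. In words, this is vinyl in place of 4-fluorophenyl on a saturated chain carbon bound to an oxygen on an aromatic ring, which can also be read as 4-fluorobenzyl to allyl.

The same swap has been measured once, and the result was modest but beyond the scatter: a 2.1-fold higher number from compound 1 to compound 2 (0.32 log units; beyond the scatter). A single example is thin evidence, but a step of similar size and direction is expected in this assay: a 2.1-fold higher number from compound 3 to compound 4 (0.32 log units; beyond the scatter). The expected value for compound 4 is 3300 nM, with an estimated range from 1700 nM to 6500 nM.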

Compound 4, half-maximal inhibitory concentration: 3990 nM
For compound 4 the middle estimate is 1.2-fold (0.08 log units) below the measured one; the range from low to high includes it.
By their numbers in this assay, from the lowest: compounds 1, 3 and 2 (each within the scatter of the next, the first and the last beyond it); then compound 4.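

In this assay, 4-fluorobenzyl to allyl now gives a 2.5-fold higher number from compound 3 to compound 4 (0.41 log units; beyond the scatter), so the rise in the number appears on a second core and does not rest on one example: the same change on two cores in this assay, a 2.1-fold higher number (0.32 log units; beyond the scatter) from compound 1 to compound 2 and a 2.5-fold higher number (0.41 log units; beyond the scatter) from compound 3 to compound 4, 1.2-fold (0.08 log units) apart, within the scatter of two such steps The other change, (dimethylamino)methyl in place of dimethylamino, can now also be read with allyl on the oxygen, giving a 2.4-fold higher number from compound 2 to compound 4 (0.38 log units; beyond the scatter), and it agrees with the step seen with 4-fluorobenzyl: the same change on two cores in this assay, a 2.0-fold higher number (0.30 log units; within the scatter) from compound 1 to compound 3 and a 2.4-fold higher number (0.38 log units; beyond the scatter) from compound 2 to compound 4, 1.2-fold (0.08 log units) apart, within the scatter of two such steps Across these four compounds, each change moves the number the same way and by a similar size, whichever group stands at the other place.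

Since 4-fluorophenyl leaves as a whole, these compounds cannot separate the part played by the ring from that of its fluorine, a question a plain benzyl group could address. As far as these compounds go, how a longer chain ending in dimethylamino would compare also remains open.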